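Weighing a Larger Replacement at the Sulfonyl-Bound Ring

This account rests on a few compounds, and the source may have more. Where it says the series, first, only, none or still open, it means among the compounds named here.

Of the compounds shown here, three sharing one core have been measured in a functional assay on PC-3 cells (Homo sapiens) for inhibition; on this read-out higher numbers stand for weaker inhibition and lower numbers for stronger inhibition. Compound 1 `COc1cc2nc(N3CCN(S(=O)(=O)c4ccc(C(F)(F)F)cc4)CC3)nc(N)c2cc1OC` gives 27000 nM, compound 2 `COc1cc2nc(N3CCN(S(=O)(=O)c4ccc(OC(F)(F)F)cc4)CC3)nc(N)c2cc1OC` gives 25000 nM, and compound 3 `COc1cc2nc(N3CCN(S(=O)(=O)c4ccc5ccccc5c4)CC3)nc(N)c2cc1OC` gives 15000 nM. Compound 2 therefore holds the second highest of the three numbers; its nearest neighbour is compound 1, with a 1.1-fold lower number from compound 1 to compound 2 (0.03 log units; within the scatter), and its furthest is compound 3, with a 1.7-fold lower number from compound 2 to compound 3 (0.22 log units; within the scatter). Compound 1 and compound 3 are likewise close, with a 1.8-fold lower number from compound 1 to compound 3 (0.26 log units; within the scatter).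

The next compound, compound 4 `COc1cc2nc(N3CCN(S(=O)(=O)c4ccc(-c5ccc(S(C)(=O)=O)cc5)cc4)CC3)nc(N)c2cc1OC`, departs from compound 2 by one change: 4-(methylsulfonyl)phenyl in place of trifluoromethoxy on an aromatic carbon. Within the data shown here, two measured steps bear on it. The exchange of trifluoromethyl for trifluoromethoxy on the same aromatic carbon moved the read-out little, and the replacement of the whole 4-(trifluoromethoxy)phenyl by naphthalen-2-yl, a wider change at the same place, also stayed within the scatter. Nothing measured here involves a second attached ring, so the new group reaches beyond what the three steps cover. On this basis no step beyond the scatter is expected in this assay , though a lower number cannot be excluded.

Compound 4 is estimated at 18000 nM, within a range from 5000 nM to 60000 nM, which amounts to an expected 1.4-fold lower number from compound 2 to compound 4 (0.14 log units; within the scatter).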

Compound 4, half-maximal inhibitory concentration: 7200 nM
Beside the measured number, compound 4's estimate is 2.5-fold (0.40 log units) above it; measured number inside the range.
By their numbers in this assay, from the lowest: compound 4; then compounds 3, 2 and 1 (each within the scatter of the next).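

In this assay, among these compounds, the 4-(methylsulfonyl)phenyl group is the first change on this aromatic carbon to move the read-out beyond the scatter, with a 3.5-fold lower number from compound 2 to compound 4 (0.54 log units; beyond the scatter) and, measured against the trifluoromethyl compound, a 3.8-fold lower number from compound 1 to compound 4 (0.57 log units; beyond the scatter). The earlier steps shown here, trifluoromethoxy for trifluoromethyl and naphthalen-2-yl for the whole substituted phenyl, had stayed within the scatter, so only now does this position show a response, and it does so to a second attached ring, although the step remains modest and compound 4 still gives 7200 nM. No measurement available here accounts for the size or direction of this step.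

The compounds shown leave open whether the added ring alone or the methylsulfonyl group it carries is responsible for the step, a question that a plain phenyl at the same place, or a second ring bearing an amine or a carboxylic acid instead of methylsulfonyl, would help to settle. They also leave open whether a longer chain ending in methylsulfonyl, with no second ring, would give a similar number.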